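This account rests on a few compounds, and the source may have more. Where it says the series, first, only, none or still open, it means among the compounds named here.

Measured in an ADME assay on CHO cells (Cricetulus griseus) for inhibition, read by MTT assay; on this read-out higher numbers stand for weaker inhibition and lower numbers for stronger inhibition:

- Compound 1 (`CC(C)(C)NCc1cc(Cl)cc(Nc2nc3ccccc3n2Cc2ccc(C(F)(F)F)cc2)c1O`): 36300 nM
- Compound 2 (`CCN(CC)Cc1cc(Nc2nc3ccccc3[nH]2)ccc1O`): > 50000 nM, a limit of the assay
- Compound 3 (`CC(C)(C)NCc1cc(Cl)cc(Nc2nc3ccccc3[nH]2)c1O`): > 50000 nM, a limit of the assay

Compound 1 is the only one of the three with an actual number, 36300 nM. Compound 2 and compound 3 give no number and stand at the limit of > 50000 nM in this assay, at which 2 of the 3 values shown sit.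

Compound 4 (`CCNCc1cc(Cl)cc(Nc2nc3ccccc3n2Cc2ccc(C(F)(F)F)cc2)c1O`) carries ethyl in place of tert-butyl on an amine nitrogen.

Going by the values given here, the one measured step, an at least 1.3-fold higher number from compound 1 to compound 3 (0.13 log units; that floor lies within the scatter), is a hydrogen in place of 4-(trifluoromethyl)benzyl on an aromatic nitrogen. That is a different place from the amine nitrogen, so it gives no size for this change. Among the compounds with values here, no measured step touches the amine nitrogen, so no step beyond the scatter is expected in this assay, and neither direction is favoured.

The expected change is a 1.0-fold lower number from compound 1 to compound 4 (0.00 log units; within the scatter). For compound 4 the estimate is 36000 nM, with an expected range of 16000 nM to 50000 nM.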

Compound 4, half-maximal inhibitory concentration: 33800 nM
Beside the measured number, compound 4's estimate is 1.1-fold (0.03 log units) above it; low and high end bracket the measured number.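

In this assay the amine nitrogen now has a measured step of its own, with ethyl in place of tert-butyl giving a 1.1-fold lower number from compound 1 to compound 4 (0.03 log units; within the scatter) and so no change that can be told from the scatter. Going by these compounds alone, this is the first step in the set that joins two actual numbers, so its size can be read directly and is not merely a floor set by a limit of the assay. Nothing measured here offers a cause for this reading.

From the compounds shown here alone, it remains open how this amine nitrogen would read with a methyl group, a cyclopropyl group or a longer chain ending in a carboxylic acid, or as part of a piperidine. Going by these compounds, it also remains open whether ethyl in place of tert-butyl would read the same in a compound with hydrogen in place of 4-(trifluoromethyl)benzyl on the aromatic nitrogen.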